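This account rests on a few compounds, and the source may have more. Where it says the series, first, only, none or still open, it means among the compounds named here.

In an ADME assay on HEp-2 cells (Homo sapiens) for cytotoxicity, with a stated time of 4 days (on this read-out lower numbers stand for higher toxicity in this test and higher numbers for lower toxicity in this test), compound 1 `CC(C)S(=O)(=O)c1cn(Cc2nc3cc(Cl)ccc3n2CCCS(C)(=O)=O)c2ccccc12` gives > 100000 nM, which is a limit of the assay and not a number. Compound 2 `CS(=O)(=O)c1nn(Cc2nc3cc(Cl)ccc3n2CCO)c2cnccc12` gives > 100000 nM in this assay, again only a limit. Within the data shown here, compound 2 thus sits at the limit of > 100000 nM in this assay, at which 2 of the 2 values shown sit, so no measured number stands anywhere so far, and no step between measured compounds can be drawn.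

Compound 3 `CS(=O)(=O)c1nn(Cc2nc3cc(Cl)ccc3n2CC2COC2)c2cnccc12` differs from compound 2 by oxetan-3-yl in place of hydroxymethyl on a saturated chain carbon bound to an aromatic nitrogen. Among the measured compounds shown here, with no measured step to weigh this change against, the change is taken as neutral on this read-out. Compound 3 is therefore expected to stay at the limit of this assay, the step from compound 2 to compound 3 being expected as a step that the limit leaves unreadable from compound 2 to compound 3, none beyond the usual scatter. Compound 3 is expected to give 150000 nM in this assay, with a range from 60000 nM to 400000 nM, most likely again reported only as a limit.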

Compound 3, half-maximal cytotoxic concentration: > 100000 nM
Compound 3: only a limit was reported; the forecaster's own chance of this, stated with the estimate: 85%; the middle value is on the limit's open side.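

Compound 2 and compound 3 both stand only as limits in this assay, so no step can be read between them: the limit of > 100000 nM in this assay, at which 3 of the 3 values shown sit.

The compounds shown leave open at what concentration any of them turns cytotoxic in this assay and whether oxetan-3-yl in place of hydroxymethyl shifts that concentration at all.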